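Swapping the aromatic group on compound 1

The source may hold more compounds than are shown below. What is called first, only, known or untested is meant among the compounds shown, and "the series" means these compounds.

Compound 1 (`CN1CCN(C2CCN(c3nccc4[nH]c(-c5ccc(F)c(C(F)(F)F)c5)nc34)CC2)CC1`) is the starting point. For the measured compounds named here, in an ADME assay on CHO cells (Cricetulus griseus) for cytotoxicity, read by MTT assay (a higher number here means that more compound is tolerated, a lower number that less compound is tolerated), compound 1 gives 4800 nM as the lower of the two numbers measured so far. The other number comes from compound 2 (`Fc1ccc(-c2nc3c(N4CCC(N5CCNCC5)CC4)nccc3[nH]2)cc1C(F)(F)F`), which gives 34000 nM in the same test.

Compound 3 (`CN1CCN(C2CCN(c3nccc4[nH]c(-c5cccc(S(C)(=O)=O)c5)nc34)CC2)CC1`) is still unmeasured. It carries 3-(methylsulfonyl)phenyl in place of 4-fluoro-3-(trifluoromethyl)phenyl on an aromatic carbon, between two ring nitrogen atoms (3-(methylsulfonyl)phenyl in place of 4-fluoro-3-(trifluoromethyl)phenyl on an aromatic carbon).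

Going by the values given here, only one measured step bears on this, and only indirectly. That step is a 7.1-fold higher number from compound 1 to compound 2 (0.85 log units; beyond the scatter) and comes from hydrogen in place of methyl on an amine nitrogen in a ring. It lies at another place in the molecule, so it shows how far one small edit can move this number, not what swapping the aromatic group does. A rise of similar or smaller size therefore seems a reasonable, tentative expectation, and a result close to compound 1 remains possible. The expected change is a 2.9-fold higher number from compound 1 to compound 3 (0.46 log units; beyond the scatter) in this assay and is only an estimate. For compound 3 the estimated value is 14000 nM with an expected range from 4500 nM to 45000 nM in this test.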

Compound 3, half-maximal cytotoxic concentration: > 50000 nM
Compound 3: no number, only a limit (the forecaster's own chance of this, stated with the estimate: 15%); middle value at least 3.5-fold (0.55 log units) away from the limit.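

In this assay compound 3 gives > 50000 nM, which is a limit of the assay and not a number. Until now, only the edit on the amine nitrogen in a ring had been seen to shift this read-out, but the aromatic group on the carbon between two ring nitrogen atoms clearly counts too: putting 3-(methylsulfonyl)phenyl in place of 4-fluoro-3-(trifluoromethyl)phenyl gives an at least 10-fold higher number from compound 1 to compound 3 (1.01 log units; beyond the scatter). How far this step truly reaches cannot be read, and the printed size is only a lower bound set by the test: the limit of > 50000 nM in this assay, at which 1 of the 3 values shown sits.

The swap changes several things at once, so these compounds cannot separate the loss of the fluorine and trifluoromethyl groups from the arrival of the methylsulfonyl group. Going by these compounds, whether a plain phenyl, or a phenyl carrying a nitrile or a carboxylic acid, would behave like compound 3 stays open, as does what happens when 3-(methylsulfonyl)phenyl is combined with hydrogen in place of methyl on the ring amine nitrogen.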